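Cyclopropyl for ethyl on the sulfonamide nitrogen

The source may hold more compounds than are shown below. What is called first, only, known or untested is meant among the compounds shown, and "the series" means these compounds.

Measured compounds:
Compound 1, `CN1C(=O)C(c2ccccc2Cl)N(C)c2nc(Nc3ccc(S(N)(=O)=O)cc3)ncc21`, 129 nM
Compound 2, `CNS(=O)(=O)c1ccc(Nc2ncc3c(n2)N(C)C(c2ccccc2C)C(=O)N3C)cc1`, 104 nM
Compound 3, `CCNS(=O)(=O)c1ccc(Nc2ncc3c(n2)N(C)C(c2ccccc2C)C(=O)N3C)cc1`, 119 nM

These three compounds share one core and differ only at the sulfonamide end and in one ring substituent. In an assay on Sf9 cells for inhibition of serine/threonine-protein kinase 4 (Homo sapiens), read by luminescence and ADP-Glo, with a stated time of 1 h, in the presence of a further agent that is not named here (a lower number here means a stronger inhibitor, a higher number a weaker inhibitor), compound 3 gives 119 nM, which is the second highest of the three numbers; its nearest neighbour is compound 1 and its furthest is compound 2, and both gaps lie within the scatter, so the three compounds cannot be told apart on these numbers.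

Compound 4, `Cc1ccccc1C1C(=O)N(C)c2cnc(Nc3ccc(S(=O)(=O)NC4CC4)cc3)nc2N1C`, has not been measured. It differs from compound 3 by cyclopropyl in place of ethyl on a sulfonamide nitrogen. For the measured compounds named here, one measured step bears on this position: a 1.1-fold higher number from compound 2 to compound 3 (0.06 log units; within the scatter). Growing the group on the sulfonamide nitrogen from hydrogen to methyl changed nothing beyond the scatter, so a further change to a small ring at the same place is expected to leave the number about where it stands, with a 1.0-fold higher number from compound 3 to compound 4 (0.00 log units; within the scatter) as the expected step. Compound 4 is therefore estimated at 120 nM, with a likely range from 60 nM to 240 nM.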

Compound 4, half-maximal inhibitory concentration: 53 nM
Beside the measured number, compound 4's estimate is 2.3-fold (0.35 log units) above it; measured number outside the range, below it.
By their numbers in this assay, from the lowest: compounds 4, 2, 3 and 1 (each within the scatter of the next, the first and the last beyond it).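

For the compounds shown here, the sulfonamide nitrogen is less indifferent to its group than the earlier compounds suggested: in this assay, cyclopropyl in place of ethyl gives a modest step beyond the scatter (a 2.2-fold lower number from compound 3 to compound 4 (0.35 log units; beyond the scatter)). Cyclopropyl in place of methyl stays within the scatter (a 2.0-fold lower number from compound 2 to compound 4 (0.29 log units; within the scatter)), so compound 4 can be told apart from compound 3 but not from compound 2, and the effect of the ring rests on a single comparison. Nothing in the data shown explains why the ring and the ethyl group differ.

On these data alone, it remains open whether a branched isopropyl group or a larger ring such as cyclobutyl on the same nitrogen would follow cyclopropyl or ethyl. As far as these compounds go, it is also open whether the cyclopropyl step would hold with the chlorine of compound 1 on the shared core's aryl ring.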